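Nitro in Place of Methyl on the Aryl Ring

A few compounds are considered here, and "the series" means these few. Any claim that something is new, unique, unknown or untested is made for them only; others in the source may bear on it.

Measured compounds:
Compound 1, `Cc1ccc(-c2noc(CCCCCCC(=O)NO)n2)cc1`, gives 5390 nM in an assay on isolated protein for inhibition of histone deacetylase 8 (Homo sapiens), read by fluorescence, with a stated time of 10 min; a higher number here means a weaker inhibitor, a lower number a stronger inhibitor.
Compound 2, `O=C(CCCCCCc1nc(-c2ccc(F)cc2)no1)NO`, gives 8760 nM in this assay.
Compound 3, `Cc1ccc(-c2noc(CCCCCCC(=O)Nc3ccccc3N)n2)cc1`, gives 8390 nM in this assay.

Compound 3 sits among the three numbers: from compound 1 the step is a 1.6-fold higher number from compound 1 to compound 3 (0.19 log units; within the scatter), and its value and that of compound 2 lie within the scatter of each other, so none of the three can be told apart with confidence. Compound 4, `Nc1ccccc1NC(=O)CCCCCCc1nc(-c2ccc([N+](=O)[O-])cc2)no1`, has not yet been measured. It differs from compound 3 by one change: nitro in place of methyl on an aromatic carbon. For the measured compounds named here, the only measured step at this same place on the ring is a 1.6-fold higher number from compound 1 to compound 2 (0.21 log units; within the scatter), where a fluoro took the place of the methyl and the number hardly moved. The step of a 1.6-fold higher number from compound 1 to compound 3 (0.19 log units; within the scatter), at the other end of the molecule, was equally small. With only these to go on, no shift beyond the scatter is expected from the nitro group, in either direction. Compound 4 is therefore estimated to give about 8000 nM in this assay, within a range of 3500 nM to 18000 nM, a step expected to be a 1.0-fold lower number from compound 3 to compound 4 (0.02 log units; within the scatter).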

Compound 4, half-maximal inhibitory concentration: > 10000 nM
Compound 4 ended at the assay's limit; the forecaster's own chance of this, stated with the estimate: 5%; at least 1.2-fold (0.09 log units) between middle value and limit.
By their numbers in this assay, from the lowest: compounds 1, 3 and 2 (each within the scatter of the next). At a limit, above all of these: compound 4.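

Putting nitro in place of methyl on this aromatic carbon, para to a large group, gives an at least 1.1-fold higher number from compound 3 to compound 4 (0.07 log units; that floor lies within the scatter) in this assay. That figure is only a floor, so the true size of the change stays hidden. Compound 4 gives > 10000 nM, which is a limit of the assay and not a number, and it is the only such result among the compounds shown: the limit of > 10000 nM in this assay, at which 1 of the 4 values shown sits. What is new is that this place on the ring has now been changed with the 2-aminophenyl group on the amide-type nitrogen, not only with hydroxy there, as in the fluoro step, a 1.6-fold higher number from compound 1 to compound 2 (0.21 log units; within the scatter), and that this time the result has no upper end, so the step may be as small as that one or far larger.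

Still open, going by these compounds, is how far compound 4 really lies from compound 3, and whether nitro would give a readable number with hydroxy on the amide-type nitrogen. Also open, on these data alone, is what an amine or a carboxylic acid at this place on the ring, or a longer chain in the middle of the molecule, would do in this assay.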